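Two methyl additions on one amide kinase-inhibitor series

The source may report more compounds than this note shows. Statements on the series, on what has been measured and on what is new or still open speak of the compounds shown alone.

Compound 1 `Cc1c(C(=O)Nc2ccc(Oc3ncnc4[nH]cc(-c5ccccc5)c34)c(F)c2)c(=O)c2ccccc2n1C` is the weakest-characterised member: in an assay on isolated protein for inhibition of tyrosine-protein kinase receptor UFO (Homo sapiens), read by FRET and Z'-LYTE, with a stated time of 1.5 h (on this read-out higher numbers stand for weaker inhibition and lower numbers for stronger inhibition), compound 1 gives > 10000 nM, which is a limit of the assay and not a number. Compound 2 `Cc1ccc2c(c1)c(=O)c(C(=O)Nc1ccc(Oc3ncnc4[nH]cc(-c5ccccc5)c34)c(F)c1)c(C)n2C` gives 100 nM in this assay. The step between them, an at least 100-fold lower number from compound 1 to compound 2 (2.00 log units; beyond the scatter), comes from methyl in place of hydrogen on an aromatic carbon. Its size is bounded only on one side, because the limit of > 10000 nM in this assay, at which 1 of the 3 values shown sits, fixes where compound 1 sits.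

Compound 3 `CCc1ccc2c(c1)c(=O)c(C(=O)Nc1ccc(Oc3ncnc4[nH]cc(-c5ccccc5)c34)cc1)c(C)n2C` gives 105 nM in this assay, a value within the scatter of that of compound 2. The difference between the cores of compound 3 and compound 1 is not broken down here.

Compound 4 `CCc1ccc2c(c1)c(=O)c(C(=O)Nc1ccc(Oc3ncnc4[nH]cc(-c5ccccc5)c34)c(C)c1)c(C)n2C` has not yet been measured. It differs from compound 3 by methyl in place of hydrogen on an aromatic carbon. Within the data shown here, this is the same kind of change as the one from compound 1 to compound 2, not the same change: there the methyl entered on a ring that is part of a fused or bridged system of two rings, meta to a fused ring and para to a fused ring; here it enters on a six-membered aromatic ring of carbon only, ortho to a large group and meta to a large group. The earlier step therefore gives no direct measure for this one.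

For compound 4 the step of a 1.0-fold higher number from compound 3 to compound 4 (0.02 log units; within the scatter) in this assay is expected to stay within the scatter, since the measured pair compound 2 and compound 3 shows that single small changes on this series can leave the number essentially unmoved. Compound 4 is accordingly estimated at 110 nM, with a range from 30 nM to 400 nM.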

Compound 4, half-maximal inhibitory concentration: 1120 nM
Compound 4: middle estimate off by 10-fold (1.01 log units), on the low side; the whole stated range lies below it.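

In this assay, methyl in place of hydrogen on an aromatic carbon gives an 11-fold higher number from compound 3 to compound 4 (1.03 log units; beyond the scatter), so this change does not carry over as a single effect from one core to another in this series, and its direction reverses: the same change on two cores in this assay, an at least 100-fold lower number (2.00 log units; beyond the scatter) from compound 1 to compound 2 and an 11-fold higher number (1.03 log units; beyond the scatter) from compound 3 to compound 4, at least 1000-fold (3.02 log units) apart, beyond the scatter of two such steps

The two methyl groups enter at different places, the later one on a six-membered aromatic ring of carbon only, ortho to a large group and meta to a large group, so the pair does not show whether the core or the place of the methyl decides the outcome. Nor does the pair give the full size of the earlier step, since compound 1 stands at a limit and not at a number: the limit of > 10000 nM in this assay, at which 1 of the 4 values shown sits.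

Open, from the compounds shown here alone, is how methyl at the place it holds in compound 4 would read on the core of compound 1 or on that of compound 2. Also open, going by these compounds, is whether the value of compound 4, 1120 nM, belongs to methyl alone or would recur with chlorine, a methoxy group or an amine at the same place on the core of compound 3.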